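Dimethoxyphenyl Variation on a Weak Aortic Series

The source may hold more compounds than are shown below. What is called first, only, known or untested is meant among the compounds shown, and "the series" means these compounds.

Compound 1 `CCOc1nc(-c2cc3ccccc3o2)cc(-c2ccc3ccccc3c2)c1C#N` and compound 2 `CCOc1nc(-c2cc3ccccc3o2)cc(-c2ccc(C)cc2)c1C#N` share one core and differ only in the aromatic group attached to it. In a functional assay on aorta (strain Wistar) for inhibition, with Thoracic aorta (Rattus norvegicus) as the target (a higher number here means a weaker inhibitor, a lower number a stronger inhibitor), compound 1 gives 423000 nM. Compound 2, which carries a 4-methylphenyl group in place of the naphthalen-2-yl group, gives 290000 nM in this assay, and the step of a 1.5-fold lower number from compound 1 to compound 2 (0.16 log units; within the scatter) is small enough to count as no real change. Among the two compounds measured so far, compound 2 has the lowest number, with compound 1 as its nearest neighbour.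

Compound 3 `CCOc1nc(-c2cc3ccccc3o2)cc(-c2ccc(OC)cc2OC)c1C#N` is the next member of this set; the change from compound 2 is 2,4-dimethoxyphenyl in place of 4-methylphenyl on an aromatic carbon. Among the compounds with values here, the only measured step at this position, a 1.5-fold lower number from compound 1 to compound 2 (0.16 log units; within the scatter), stayed within the scatter, so the one piece of evidence on swapping aromatic groups here points to little movement in this assay. On that basis compound 3 is expected to show a step of about a 1.0-fold higher number from compound 2 to compound 3 (0.01 log units; within the scatter), with no clear direction. The estimate for compound 3 in this assay is 300000 nM, with a likely range from 100000 nM to 900000 nM.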

Compound 3, half-maximal inhibitory concentration: 488000 nM
Compound 3: the middle estimate sits 1.6-fold (0.21 log units) below what was measured; the measured number falls inside the stated range.
By their numbers in this assay, from the lowest: compounds 2, 1 and 3 (each within the scatter of the next).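

In this assay, replacing 4-methylphenyl with 2,4-dimethoxyphenyl gives a step that stays within the scatter (a 1.7-fold higher number from compound 2 to compound 3 (0.23 log units; within the scatter)), and replacing naphthalen-2-yl with the same group does too (a 1.2-fold higher number from compound 1 to compound 3 (0.06 log units; within the scatter)). Within the data shown here, this widens the earlier picture: 2,4-dimethoxyphenyl is the first group here to bring oxygen atoms and hydrogen-bond acceptors to this position, opposite the ring nitrogen, yet the three compounds still cannot be told apart in this assay. Nothing else available helps to explain this result.

On these data alone, all three groups at this position are aromatic rings of carbon only, so it remains open whether a pyridinyl ring, or a phenyl ring carrying an amine or a carboxylic acid, would move the number beyond the scatter. As far as these compounds go, the ethoxy, cyano and 1-benzofuran-2-yl groups are the same in all three compounds, so the effect of changing any of them on the aorta read-out also remains unknown.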